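Hydroxyphenyl in place of fluorophenyl on the shared core

A few compounds are considered here, and "the series" means these few. Any claim that something is new, unique, unknown or untested is made for them only; others in the source may bear on it.

Measured compounds:
compound 1, `Clc1ccc(-c2cn(Cc3ccccc3)c3c2CNCC3)c(Cl)c1`, 2070 nM
compound 2, `O=[N+]([O-])c1ccc(-c2cn(Cc3ccccc3)c3c2CNCC3)cc1`, 450 nM
compound 3, `Fc1cccc(-c2cn(Cc3ccccc3)c3c2CNCC3)c1`, 2730 nM

All three were tested in an assay on HEK293 cells for displacement of a labelled ligand from 5-hydroxytryptamine receptor 7 (Rattus norvegicus), with a stated time of 60 min; a lower number here means a stronger inhibitor, a higher number a weaker inhibitor. Compound 3 holds the highest of the three numbers; its nearest neighbour is compound 1, and the step of a 1.3-fold higher number from compound 1 to compound 3 (0.12 log units; within the scatter) lies within the scatter. Compound 2 stands furthest away, and the two values of compound 3 and compound 2 differ beyond the scatter.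

Compound 4 is `Oc1ccc(-c2cn(Cc3ccccc3)c3c2CNCC3)cc1`. It differs from compound 3 in one place: 4-hydroxyphenyl in place of 3-fluorophenyl on an aromatic carbon. Within the data shown here, no measured step replaces a fluorophenyl by a hydroxyphenyl, so the bearing of the measured steps is indirect. The step from compound 1 to compound 3 shows that swapping one halogenated phenyl for another changed little. The gap between compound 3 and compound 2 shows that a different substituent on that phenyl can move the number substantially in this assay. A change toward a lower number is therefore expected, but with wide uncertainty. Compound 4 is estimated at 1400 nM, with a range from 350 nM to 5600 nM, which corresponds to an expected step of a 2.0-fold lower number from compound 3 to compound 4 (0.29 log units; within the scatter).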

Compound 4, inhibition constant: 10000 nM
Beside the measured number, compound 4's estimate is 7.1-fold (0.85 log units) below it; the measured number lies above the stated range.
By their numbers in this assay, from the lowest: compound 2; then compounds 1 and 3 (each within the scatter of the next); then compound 4.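

On this aromatic carbon of the shared core, 4-hydroxyphenyl gives the first steps toward a higher number in this assay that lie beyond the scatter: a 3.7-fold higher number from compound 3 to compound 4 (0.56 log units; beyond the scatter) and a 4.8-fold higher number from compound 1 to compound 4 (0.68 log units; beyond the scatter). The earlier compounds had shown only that 3-fluorophenyl and 2,4-dichlorophenyl could not be told apart here, and that the nitro-bearing compound 2 stood at a lower number; the exchange of nitro for hydroxy now gives a 22-fold higher number from compound 2 to compound 4 (1.35 log units; beyond the scatter), so the substituent on this phenyl can move the number a long way, and this is the widest step among the compounds shown. Nothing measured here accounts for these steps.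

The change from compound 3 to compound 4 alters both the substituent and its place on the phenyl, so the compounds shown do not separate the two, and a 3-hydroxyphenyl or a 4-fluorophenyl group at this carbon would bear on that. They also leave open how a 4-methoxyphenyl or a 4-aminophenyl group would stand in this assay relative to the hydroxy and nitro compounds.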